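A few compounds are considered here, and "the series" means these few. Any claim that something is new, unique, unknown or untested is made for them only; others in the source may bear on it.

Measured compounds:
- Compound 1, `O=C1/C(=C/c2ccccc2)CCC/C1=C\c1ccccc1Cl`: "not determined" (no result reported) in an assay on isolated protein for inhibition of Alpha glucosidase (Homo sapiens), with stated times of 5 min and 15 min; on this read-out lower numbers stand for stronger inhibition and higher numbers for weaker inhibition
- Compound 2, `O=C1/C(=C/c2ccccc2)CCC/C1=C\c1cccc(Cl)c1Cl`: "not determined" (no result reported) in this assay
- Compound 3, `O=C(/C=C(O)/C=C/c1ccc(O)c(O)c1)c1cc(Cl)ccc1O`: 15100 nM

Compound 1 stands without a number of its own in this assay, and compound 2 is a further entry without a single number, so the only measured figure in the set belongs to compound 3. Compound 3 shares no common core with compound 1, so its value offers a rough anchor rather than a step.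

The step from compound 1 to compound 4, `O=C1/C(=C/c2ccccc2)CCC/C1=C\c1cccc(O)c1`, is the following change: 3-hydroxyphenyl in place of 2-chlorophenyl on a double-bonded chain carbon bound to a double-bonded ring carbon. No step between measured compounds is shown, so the size of this step in this assay cannot be read from the data; the expectation is for a step of unknown direction that may well stay within the usual scatter, with no measured value to set its starting point.

Compound 4 is therefore expected to give roughly 20000 nM in this assay, with a wide range from 3000 nM to 120000 nM, resting on the value of compound 3 15100 nM as the only measured reference.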

Compound 4, half-maximal inhibitory concentration: 28400 nM
For compound 4 the middle estimate is 1.4-fold (0.15 log units) below the measured one; the measured number falls inside the stated range.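

In this assay, for the compounds shown here, compound 1 stands as "not determined" (no result reported) and compound 4 gives 28400 nM so no step between them can be read. The compounds shown leave open how 3-hydroxyphenyl compares with 2-chlorophenyl on the shared core. No evidence at hand bears on this result.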